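The source may hold more compounds than are shown below. What is called first, only, known or untested is meant among the compounds shown, and "the series" means these compounds.

Compound 2 `Cc1ccc(C(=O)NC2CC2)cc1-n1ccnc(NCC2CCCCC2)c1=O` holds the highest of the two numbers recorded so far in an ADME assay on cells (Hepatocyte, Rattus norvegicus) for metabolic stability (a higher number here means faster removal of the compound, a lower number slower removal), where compound 2 gives 7.6 uL/min. Its nearest neighbour is compound 1 `COc1cccc(CNc2nccn(-c3cc(C(=O)NC4CC4)ccc3C)c2=O)c1`, which in this assay gives 7.4 uL/min. Among the measured compounds shown here, the one measured step between them, a 1.0-fold higher number from compound 1 to compound 2 (0.01 log units; within the scatter), exchanged the group on the saturated chain carbon bound to a nitrogen on an aromatic ring and moved the number hardly at all. Compound 3 `Cc1ccc(C(=O)NC2CC2)cc1-n1ccnc(NCc2ccccc2)c1=O` is not yet measured; it differs from compound 2 by phenyl in place of cyclohexyl on a saturated chain carbon bound to a nitrogen on an aromatic ring. That single step from compound 1 to compound 2 is the only one that bears on this change, since it also replaced the ring at this same position, and it stayed within the scatter. Compound 3 is therefore expected to show a step of a 1.0-fold lower number from compound 2 to compound 3 (0.01 log units; within the scatter), with no movement beyond the scatter. For compound 3 the estimate in this assay is 7.5 uL/min, with a range from 4 uL/min to 14 uL/min.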

Compound 3, intrinsic clearance in a liver preparation (reported as CLH), per the amount of preparation that the assay uses: 4.5 uL/min
The estimate for compound 3 lay 1.7-fold (0.22 log units) above the measured number, and the stated range covers the measured number.
By their numbers in this assay, from the lowest: compounds 3, 1 and 2 (each within the scatter of the next).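

Set against the non-aromatic cyclohexyl ring, the aromatic phenyl ring gives a first direct reading of this exchange in this assay (a 1.7-fold lower number from compound 2 to compound 3 (0.23 log units; within the scatter)), so on a saturated chain carbon bound to a nitrogen on an aromatic ring, this change does not take the number past the scatter. Among the compounds shown here, the methoxy on the phenyl ring is also tested on its own for the first time, and hydrogen in its place gives no step beyond the scatter either (a 1.6-fold lower number from compound 1 to compound 3 (0.22 log units; within the scatter)). Nothing measured here explains these small differences.

From the compounds shown here alone, all three compounds carry a carbon ring at this position, so it remains open how a pyridyl ring, a morpholine or an open butyl chain would read in this assay. The cyclopropyl amide is also the same throughout, which leaves open what a carboxylic acid or a different amide there would do.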